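The compounds below may be only part of what the source reports. "The series", "measured", "known", "first", "only" and "open" are said of these compounds alone.

Measured so far in a functional assay on JeKo-1 cells (Homo sapiens) for inhibition, read by luminescence and CellTiter-Glo, with a stated time of 72 h; on this read-out higher numbers stand for weaker inhibition and lower numbers for stronger inhibition:
compound 1, `O=C(CCl)Nc1ccc(Cn2nc(-c3ccc(Oc4ccccc4)cc3)cc2CO)cc1`: 400 nM
compound 2, `C/C=C/C(=O)Nc1cccc(Cn2nc(-c3ccc(Oc4ccccc4)cc3)cc2C(=O)O)c1`: > 60000 nM (a limit of the assay, not a number)
compound 3, `C/C=C/C(=O)Nc1cccc(Cn2nc(-c3ccc(Oc4ccccc4)cc3)cc2C(=O)OCC)c1`: 16700 nM

The three compounds share one core and differ in two places: in the amide-bearing group on the saturated chain carbon bound to the aromatic nitrogen, and in the group on the core that is a hydroxymethyl in compound 1, a carboxylic acid in compound 2 and an ethyl ester in compound 3. Among the two numbers measured, compound 3 stands at the highest; compound 1 gives a lower number. For compound 2 only a limit is known. Replacing the acid by its ethyl ester gives an at least 3.5-fold lower number from compound 2 to compound 3 (0.55 log units; beyond the scatter); because this step rests on (the limit of > 60000 nM in this assay, at which 1 of the 3 values shown sits), only its lower bound is known.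

Compound 4, `CCOC(=O)c1cc(-c2ccc(Oc3ccccc3)cc2)nn1Cc1ccc(NC(=O)CCl)cc1`, differs from compound 3 by 4-(((chloromethyl)carbonyl)amino)phenyl in place of 3-(((prop-1-en-1-yl)carbonyl)amino)phenyl on a saturated chain carbon bound to an aromatic nitrogen. Among the measured compounds shown here, no measured step covers exactly this change. Compound 1 carries the same amide-bearing group as compound 4 but a hydroxymethyl where compound 4 has the ethyl ester, and in this assay compound 1 gives 400 nM. Since the ester of compound 3 did not fall behind the acid of compound 2, the amide-bearing group of compound 1 is expected to carry much of its lower number over to the ester. Compound 4 is therefore estimated at about 1500 nM, between 300 nM and 8000 nM, an expected step of an 11-fold lower number from compound 3 to compound 4 (1.05 log units; beyond the scatter).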

Compound 4, half-maximal inhibitory concentration: 400 nM
Beside the measured number, compound 4's estimate is 3.8-fold (0.57 log units) above it; low and high end bracket the measured number.
By their numbers in this assay, from the lowest: compounds 1 and 4 (each within the scatter of the next); then compound 3. At a limit, above all of these: compound 2.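

In this assay, with the ethoxycarbonyl held the same on the shared core, the group on the saturated chain carbon bound to an aromatic nitrogen turns out to matter a great deal, with a 42-fold lower number from compound 3 to compound 4 (1.62 log units; beyond the scatter) when 4-(((chloromethyl)carbonyl)amino)phenyl replaces 3-(((prop-1-en-1-yl)carbonyl)amino)phenyl. With that 4-(((chloromethyl)carbonyl)amino)phenyl group in place, the other changing site shows no change at the digits printed from compound 1 to compound 4 (within the scatter) so that hydroxymethyl and ethoxycarbonyl on the aromatic carbon cannot be told apart in this pair. What lies behind either step is not shown by the data at hand.

The large step changes two things at once, the chain on the carbonyl and the number in the group's name, so 3-(((chloromethyl)carbonyl)amino)phenyl or 4-(((prop-1-en-1-yl)carbonyl)amino)phenyl on the same ester would be needed to separate the two. Also open, from the compounds shown here alone, is how the 4-(((chloromethyl)carbonyl)amino)phenyl group behaves with a carboxylic acid on the core, and whether a plain acetyl in place of the chloromethyl-bearing carbonyl keeps the number of compound 4.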